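Swapping the carbamate aryl group: pyridine to fluorophenyl

The source may hold more compounds than are shown below. What is called first, only, known or untested is meant among the compounds shown, and "the series" means these compounds.

Measured so far:
Compound 1 `CCCCOc1ccc(C(CC)NC(=O)Oc2ccc(F)cc2)cc1`: 12 nM
Compound 2 `CCCCOc1ccc(CNC(=O)Oc2ccc(F)cc2F)cc1`: 8.7 nM
Compound 3 `CCCCOc1ccc(CNC(=O)Oc2cccnc2)cc1`: 6.1 nM

Three carbamates sharing one core were tested in an assay on H4 cells for inhibition of Fatty-acid amide hydrolase 1 (Homo sapiens); a lower number here means a stronger inhibitor, a higher number a weaker inhibitor. In this assay compound 1 gives 12 nM, compound 2 gives 8.7 nM and compound 3 gives 6.1 nM. Compound 3 does not separate from either neighbour: its gaps to compound 2 and to compound 1 both sit within the usual scatter, so the three cannot be ranked on these numbers.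

Compound 4 `CCCCOc1ccc(CNC(=O)Oc2ccc(F)cc2)cc1` has not yet been measured. It differs from compound 3 in one place: 4-fluorophenyl in place of pyridin-3-yl on an oxygen next to a carbonyl group. Going by the values given here, the only measured step that touches the same position is a 1.4-fold lower number from compound 2 to compound 3 (0.15 log units; within the scatter), a change that stayed within the scatter. Exchanging one aryl group for another on this oxygen therefore gave no clear shift, and the same is expected here: compound 4 is expected to show no step beyond the scatter in this assay, a 1.5-fold higher number from compound 3 to compound 4 (0.17 log units; within the scatter). Compound 4 is estimated at 9 nM, with a likely range from 4 nM to 20 nM.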

Compound 4, half-maximal inhibitory concentration: 4.6 nM
The estimate for compound 4 lay 2.0-fold (0.29 log units) above the measured number, within the range that was stated.
By their numbers in this assay, from the lowest: compounds 4, 3, 2 and 1 (each within the scatter of the next, the first and the last beyond it).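

Another exchange on an oxygen next to a carbonyl group, 4-fluorophenyl in place of pyridin-3-yl, stays within the scatter in this assay (a 1.3-fold lower number from compound 3 to compound 4 (0.12 log units; within the scatter)), so pyridin-3-yl, 4-fluorophenyl and 2,4-difluorophenyl now all give numbers within the scatter of one another. Hydrogen in place of fluoro on an aromatic carbon also stays within the scatter (a 1.9-fold lower number from compound 2 to compound 4 (0.28 log units; within the scatter)). Going by these compounds alone, the one step beyond the scatter lies at a different place, where hydrogen replaces ethyl on a saturated chain carbon bound to an amide-type nitrogen and an aromatic carbon (a 2.6-fold lower number from compound 1 to compound 4 (0.42 log units; beyond the scatter)).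

No supporting data are available to explain these numbers. From the compounds shown here alone, it remains open whether a non-aromatic group on this oxygen, such as a cyclohexyl ring, or a carboxylic acid on the aromatic ring would shift the number beyond the scatter.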